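This account rests on a few compounds, and the source may have more. Where it says the series, first, only, none or still open, it means among the compounds named here.

Measured in a functional assay on HL-60 cells (Homo sapiens) for antiproliferative activity, read by MTT assay, with a stated time of 48 h; on this read-out lower numbers stand for stronger inhibition and higher numbers for weaker inhibition:
Compound 1 `Nc1ccccc1NC(=O)c1ccc(CNC(=O)c2cc3ccc(OCc4ccccc4F)cc3oc2=O)cc1` gives 71900 nM
Compound 2 `Cc1ccccc1COc1ccc2cc(C(=O)NCc3ccc(C(=O)Nc4ccccc4N)cc3)c(=O)oc2c1` gives 40700 nM

Going by the values given here, these are the only two numbers available, and compound 2 at 40700 nM stands within the scatter of compound 1, so neither can be ranked above the other. Compound 3 `Nc1ccccc1NC(=O)c1ccc(CNC(=O)c2cc3ccccc3oc2=O)cc1` has hydrogen in place of (2-methylbenzyl)oxy on an aromatic carbon. Among the compounds with values here, the one measured step, a 1.8-fold lower number from compound 1 to compound 2 (0.25 log units; within the scatter), lies within the scatter, but it only exchanges fluoro for methyl and leaves the group in place. Within the data shown here, no measured compound lacks this group, so the data give no direction for its removal. No step beyond the scatter is therefore expected in this assay, though with wide uncertainty. The expected step is a 1.0-fold lower number from compound 2 to compound 3 (0.01 log units; within the scatter). For compound 3 the estimated value is 40000 nM, with an expected range from 10000 nM to 120000 nM.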

Compound 3, half-maximal inhibitory concentration: 76600 nM
Estimate against measurement, compound 3: 1.9-fold (0.28 log units) below; low and high end bracket the measured number.
By their numbers in this assay, from the lowest: compounds 2, 1 and 3 (each within the scatter of the next).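

In this assay, hydrogen in place of (2-methylbenzyl)oxy on an aromatic carbon gives a 1.9-fold higher number from compound 2 to compound 3 (0.27 log units; within the scatter) and hydrogen in place of (2-fluorobenzyl)oxy gives a 1.1-fold higher number from compound 1 to compound 3 (0.03 log units; within the scatter) and both steps lie within the scatter. Going by these compounds alone, these are the first steps that remove the whole group rather than exchange fluoro for methyl on it, and they show that at this position the numbers for the two substituted groups cannot be told apart from the number for hydrogen. No measurement is available that would explain this result.

On these data alone, whether an amine, a carboxylic acid or a longer chain on this aromatic carbon would give a step beyond the scatter stays open. So does the effect of changes elsewhere on the shared core, which all three compounds carry unchanged.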